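Halogen swap transferred to the benzamido member

The source may hold more compounds than are shown below. What is called first, only, known or untested is meant among the compounds shown, and "the series" means these compounds.

Compound 1 `O=C(Nn1c(-c2cccc([N+](=O)[O-])c2)nc2c(-c3ccc(Cl)cc3)n[nH]c2c1=O)c1cccnc1` gives 31% in a functional assay on DU-145 cells (Homo sapiens) for cytotoxicity, read by sulforhodamine B assay, with a stated time of 2 days, tested at 100 uM; a lower number here means less inhibition, a higher number more inhibition at the concentration tested (going by the name of the read-out). Compound 2 `O=C(Nn1c(-c2cccc([N+](=O)[O-])c2)nc2c(-c3ccc(F)cc3)n[nH]c2c1=O)c1cccnc1` carries fluoro in place of chloro on an aromatic carbon and in this assay gives 24.9%, a step of a number 6.1 percentage points lower from compound 1 to compound 2 (within the scatter). For the measured compounds named here, compound 3 `O=C(Nn1c(-c2cccc([N+](=O)[O-])c2)nc2c(-c3ccc(Cl)cc3)n[nH]c2c1=O)c1ccccc1` differs from compound 1 by phenyl in place of pyridin-3-yl on a carbonyl carbon; in this assay compound 3 gives 94.3%, a step of a number 63.3 percentage points higher from compound 1 to compound 3 (beyond the scatter), the highest of the three numbers so far. Compound 4 `O=C(Nn1c(-c2cccc([N+](=O)[O-])c2)nc2c(-c3ccc(F)cc3)n[nH]c2c1=O)c1ccccc1`, still unmeasured, is compound 3 with fluoro in place of chloro on an aromatic carbon; the same change, at a place described in the same words, was made from compound 1 to compound 2, the two pairs differing only in the cores just described. Because a number 6.1 percentage points lower from compound 1 to compound 2 (within the scatter) stayed within the scatter, the step from compound 3 to compound 4 is expected to be small as well. The expected step is a number 6.3 percentage points lower from compound 3 to compound 4 (within the scatter). Compound 4 is estimated at 88%, between 70% and 98%.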

Compound 4, a percentage reported as inhibition, at one concentration (the size of the read-out at that concentration, not a potency): 90.8%
Compound 4: middle estimate off by 2.8 percentage points, on the low side; the range from low to high includes it.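

In this assay the change from 4-chlorophenyl to 4-fluorophenyl stays small on the phenyl member, with a number 3.5 percentage points lower from compound 3 to compound 4 (within the scatter), and matches the step on the pyridin-3-yl member: the same change on two cores in this assay, a number 6.1 percentage points lower (within the scatter) from compound 1 to compound 2 and a number 3.5 percentage points lower (within the scatter) from compound 3 to compound 4, 2.6 percentage points apart, within the scatter of two such steps

The change from pyridin-3-yl to phenyl on the carbonyl carbon also carries over to the fluoro pair, with a number 65.9 percentage points higher from compound 2 to compound 4 (beyond the scatter), and matches the step on the chloro pair: the same change on two cores in this assay, a number 63.3 percentage points higher (beyond the scatter) from compound 1 to compound 3 and a number 65.9 percentage points higher (beyond the scatter) from compound 2 to compound 4, 2.6 percentage points apart, within the scatter of two such steps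

This shows that the two changes behave consistently across these four compounds, but only at one concentration in one cell line; it gives no potency and does not show the same transfer on other cores.

Still open, as far as these compounds go, is what an amine or a methoxy group in place of the halogen would give. Also open, from the compounds shown here alone, is whether a thiophene or a pyridin-4-yl group on the carbonyl carbon would read like phenyl or like pyridin-3-yl.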